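A few compounds are considered here, and "the series" means these few. Any claim that something is new, unique, unknown or untested is made for them only; others in the source may bear on it.

Compound 1 `CCOc1ccc(C2CC2C(=O)NNC(=O)c2ccncc2)cc1` was tested in a functional assay on U-373MG ATCC cells (Homo sapiens) for inhibition, read by MTT assay, with a stated time of 72 h (a higher number here means a weaker inhibitor, a lower number a stronger inhibitor), where compound 1 gives 63000 nM. Two related compounds share its core. Among the compounds with values here, compound 2 `CCOc1ccc(C2CC2C(=O)NNc2nncc3ccccc23)cc1` gives 91000 nM in this assay, a number that lies within the usual scatter of the one for compound 1, so the two cannot be told apart. Within the data shown here, compound 3 `CC(C)=CCC/C(C)=C/COc1ccc(C2CC2C(=O)NNc2nncc3ccccc23)cc1` gives 9000 nM in this assay; of the three numbers, the one for compound 1 is the second highest, and only compound 3 is clearly apart from it. Compound 4 `COc1ccc(C2CC2C(=O)NNC(=O)c2ccncc2)cc1` has not yet been measured. It differs from compound 1 by hydrogen in place of methyl on a saturated chain carbon bound to an oxygen on an aromatic ring. Among the measured compounds shown here, no measured step makes exactly this change. For the measured compounds named here, the only step at the same place is a 10-fold lower number from compound 2 to compound 3 (1.00 log units; beyond the scatter), in which a much larger group replaced the methyl. The change to compound 4 goes the other way and is far smaller, so only a small shift, if any, toward a higher number is expected, and a 1.4-fold higher number from compound 1 to compound 4 (0.15 log units; within the scatter) is the estimated step. Compound 4 is therefore expected to give about 90000 nM in this assay, with a likely range from 40000 nM to 200000 nM.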

Compound 4, half-maximal inhibitory concentration: > 100000 nM
Compound 4: only a limit was reported (the forecaster's own chance of this, stated with the estimate: 15%); middle value at least 1.1-fold (0.04 log units) from the limit.
By their numbers in this assay, from the lowest: compound 3; then compounds 1 and 2 (each within the scatter of the next). At a limit, above all of these: compound 4.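

Compound 4 gives > 100000 nM in this assay, which is a limit of the assay and not a number. Where the earlier compounds showed only a much larger group at this place, on a different core, the small change from ethoxy to methoxy on the core of compound 1 can now be read directly as an at least 1.5-fold higher number from compound 1 to compound 4 (0.20 log units; that floor lies within the scatter). This floor does not establish a real loss, but the change brought no clear gain, and the true size of the step stays unknown: the limit of > 100000 nM in this assay, at which 1 of the 4 values shown sits.

As far as these compounds go, it remains open whether a propyl chain in place of the ethyl on the core of compound 1 would move the number. Also open, from the compounds shown here alone, is how the 2,6-dimethylhepta-1,5-dien-1-yl group of compound 3 would behave on the core of compound 1.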